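The source may report more compounds than this note shows. Statements on the series, on what has been measured and on what is new or still open speak of the compounds shown alone.

Working notes on the series. In a functional assay on PC-3 cells (Homo sapiens) for inhibition, read by MTT assay, with a stated time of 48 h (on this read-out higher numbers stand for weaker inhibition and lower numbers for stronger inhibition), compound 1 `C[C@H]1CCC/C=C/[C@H]2CC[C@H](O)[C@H](CC(=O)O1)O2` has the entry "not determined" (no result reported) and so offers no number for comparison. For the measured compounds named here, compound 2 `CO[C@H]1C=C[C@H]2C/C=C\C[C@H](c3ccc(Br)cc3)OC(=O)C[C@@H]1O2` gives 15800 nM as the only number so far, which means that its standing cannot yet be ranked. Compound 3 `CO[C@H]1C=C[C@H]2C/C=C\C[C@H](c3ccc(-c4ccccc4C(F)(F)F)cc3)OC(=O)C[C@@H]1O2` has still to be measured in this assay and carries a much larger substituent. The change is 2-(trifluoromethyl)phenyl in place of bromo on an aromatic carbon with 2-(trifluoromethyl)phenyl in place of bromo on an aromatic carbon, para to a large group. Going by the values given here, no step between measured compounds is available to calibrate this exchange, so the expectation rests on a single value and on the structural change alone. A moderate move toward stronger inhibition is expected, although a result within the usual scatter of compound 2 would be no surprise. The expected 2.0-fold lower number from compound 2 to compound 3 (0.30 log units; within the scatter) is therefore small and uncertain in size. The estimated value for compound 3 is 8000 nM with an expected range from 2500 nM to 25000 nM in this read-out.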

Compound 3, half-maximal inhibitory concentration: 7360 nM
Beside the measured number, compound 3's estimate is 1.1-fold (0.04 log units) above it, within the range that was stated.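

In this assay, for the compounds shown here, the exchange of bromo for 2-(trifluoromethyl)phenyl on an aromatic carbon, para to a large group, gives a 2.1-fold lower number from compound 2 to compound 3 (0.33 log units; beyond the scatter), the first step that can be read. This position therefore tolerates a much larger substituent: 10 heavy atoms and an added six-membered aromatic ring replace a single bromine, with a modest gain in inhibition rather than a loss. No measurement is available that bears on the origin of this step, so it stands as an observation only.

Comparisons involving compound 1 cannot be read, as it has no number, and the single step does not separate the contribution of the added aromatic ring from that of its trifluoromethyl group. The compounds shown also leave open how an unsubstituted phenyl, an amine or a carboxylic acid at the same position would read, and so whether the modest gain depends on the 2-(trifluoromethyl)phenyl group or would extend to other groups there.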